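Oxetane for Cyclobutane on the Carbamate of Compound 2

The compounds below may be only part of what the source reports. "The series", "measured", "known", "first", "only" and "open" are said of these compounds alone.

In a functional assay on isolated protein for inhibition of Glucose-dependent insulinotropic receptor (Homo sapiens), read by HTRF and cAMP accumulation (on this read-out higher numbers stand for an effect only at larger amounts of compound and lower numbers for an effect already at smaller amounts), compound 1 `Cc1nc(S(C)(=O)=O)ccc1Oc1ncnc(OC2CCN(C(=O)OC(C)F)CC2)c1F` gives 65.5 nM, and compound 2 `Cc1nc(S(C)(=O)=O)ccc1Oc1ncnc(OC2CCN(C(=O)OC3(C(F)(F)F)CCC3)CC2)c1F` gives 14.3 nM; the step of a 4.6-fold lower number from compound 1 to compound 2 (0.66 log units; beyond the scatter) makes compound 2 the lower of the two numbers. Compound 3 `Cc1nc(S(C)(=O)=O)ccc1Oc1ncnc(OC2CCN(C(=O)OC3(C(F)(F)F)COC3)CC2)c1F` differs from compound 2 by 3-(trifluoromethyl)oxetan-3-yl in place of 1-(trifluoromethyl)cyclobutyl on an oxygen next to a carbonyl group. For the measured compounds named here, no measured step touches this exchange; the only step at hand altered the whole group on that oxygen, so it gives little guidance. He therefore expects a step of a 1.7-fold higher number from compound 2 to compound 3 (0.24 log units; within the scatter), within or just beyond the scatter. Compound 3 is estimated at 25 nM, between 8 nM and 75 nM.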

Compound 3, half-maximal effective concentration: 29.3 nM
The estimate for compound 3 lay 1.2-fold (0.07 log units) below the measured number; the measured number falls inside the stated range.
By their numbers in this assay, from the lowest: compound 2; then compound 3; then compound 1.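

In this assay, replacing 1-(trifluoromethyl)cyclobutyl with 3-(trifluoromethyl)oxetan-3-yl gives a 2.0-fold higher number from compound 2 to compound 3 (0.31 log units; beyond the scatter), so this position on the oxygen next to a carbonyl group responds even to a change of one atom within the four-membered ring. 3-(Trifluoromethyl)oxetan-3-yl still compares well with 1-fluoroethyl, giving a 2.2-fold lower number from compound 1 to compound 3 (0.35 log units; beyond the scatter). Nothing available explains either step. The compounds shown leave open how a five-membered ring of carbon only, or a four-membered ring holding an amine, would behave at this position.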